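The source may hold more compounds than are shown below. What is called first, only, known or untested is meant among the compounds shown, and "the series" means these compounds.

Working notes on the series. Among the measured compounds shown here, compound 1 `O=c1nc2oc(CCCCl)cc2cn1Cc1cn(-c2ccccc2F)nn1` carries the shorter halogenated side chain and a fluoro-aryl group on the triazole; in a functional assay on HeLa cells (Homo sapiens) for antiproliferative activity, read by MTT assay, with a stated time of 72 h (on this read-out lower numbers stand for stronger inhibition and higher numbers for weaker inhibition), compound 1 gives 66500 nM, the only numerical value in the set. Compound 2 `CCCCCCC#Cc1c(CCCCCC)oc2nc(=O)n(Cc3cn(-c4ccc(F)cc4)nn3)cc12` carries the longer alkyl and alkynyl chains on the shared core. In this assay compound 2 returns only the assay limit, > 100000 nM. Compound 3 `CCCCCCC#Cc1c(CCCCCC)oc2nc(=O)n(Cc3cn(-c4ccc(Cl)cc4)nn3)cc12`, the chloro analogue, also returns only the assay limit in this assay, > 100000 nM. The step that the two limits leave unreadable from compound 2 to compound 3 cannot be sized because the limit of > 100000 nM in this assay, at which 2 of the 3 values shown sit, covers both ends of it. Compound 3 therefore stands at a limit, not at a number, and one further value in the set sits at the same limit.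

Compound 4 `CCCCCCC#Cc1c(CCCCCC)oc2nc(=O)n(Cc3cn(Cc4ccccc4)nn3)cc12` is the next member: benzyl in place of 4-chlorophenyl on an aromatic nitrogen. For the measured compounds named here, no measured step in the set speaks to this change, and the step on the same position from fluoro to chloro was itself unreadable. With the core of compound 3 giving no number, the expectation is that compound 4 stays at or near the limit. Compound 4 is estimated at 150000 nM, with a range of 50000 nM to 500000 nM. The implied step that the limit leaves unreadable from compound 3 to compound 4 is expected to remain unreadable against the limit.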

Compound 4, half-maximal inhibitory concentration: 23400 nM
Compound 4: middle estimate off by 6.4-fold (0.81 log units), on the high side; the measured number lies below the stated range.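

Benzyl in place of 4-chlorophenyl gives an at least 4.2-fold lower number from compound 3 to compound 4 (0.63 log units; beyond the scatter) in this assay, and benzyl in place of 4-fluorophenyl gives an at least 4.2-fold lower number from compound 2 to compound 4 (0.63 log units; beyond the scatter). The exchange of fluoro for chloro had left this position without a readable result, whereas these steps show that the group on the aromatic nitrogen can move the read-out while the longer alkyl and alkynyl chains on the shared core stay in place. Both steps give only a minimum size, not a full one, because compound 2 and compound 3 each stand at a limit and not at a number: the limit of > 100000 nM in this assay, at which 2 of the 4 values shown sit.

Going by these compounds, whether the lower number follows the added link to the aromatic ring or the loss of the halogen stays open: a plain phenyl group or a 4-chlorobenzyl group at this place would separate the two, and a phenethyl group would extend the link. Compound 1 differs from compound 4 in more than one place, so how the chains on the shared core contribute to the read-out also remains unresolved.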